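A few compounds are considered here, and "the series" means these few. Any claim that something is new, unique, unknown or untested is made for them only; others in the source may bear on it.

The measured compounds:

Compound 1, `CO[C@@H]1CC=C2NN(c3ccc([N+](=O)[O-])cc3)C(=O)CC[C@]2(c2ccccc2)O1`: in a functional assay on HCT-116 cells (Homo sapiens) for cytotoxicity, read by sulforhodamine B assay, with a stated time of 48 h (a lower number here means a stronger inhibitor, a higher number a weaker inhibitor), compound 1 gives 8700 nM.
Compound 2, `CO[C@@H]1CC=C2NN(c3ccccn3)C(=O)CC[C@]2(c2ccccc2)O1`: in this assay compound 2 gives 1400 nM.
Compound 3, `CO[C@@H]1CC=C2N(c3ccc([N+](=O)[O-])cc3)C(=O)C[C@]2(c2ccccc2)O1`: in this assay compound 3 gives 8000 nM.

Compound 1 and compound 2 share one core and differ in one place: pyridin-2-yl in place of 4-nitrophenyl on an amide-type nitrogen in a ring. This single exchange brought a 6.2-fold lower number from compound 1 to compound 2 (0.79 log units; beyond the scatter) in this assay.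

Compound 3 has a different core from compound 1; the difference between the two cores is not broken down here. What the numbers show is that compound 1 and compound 3 lie within the usual scatter of each other in this assay, so no order between them can be read.

Compound 4, `CO[C@@H]1CC=C2N(c3ccccn3)C(=O)C[C@]2(c2ccccc2)O1`, is not yet measured. It stands to compound 3 as compound 2 stands to compound 1: pyridin-2-yl in place of 4-nitrophenyl on an amide-type nitrogen in a ring. The surroundings of the place are not the same, though. In compound 1 the amide-type nitrogen sits in a seven-membered non-aromatic ring with 2 nitrogen, next to the ring nitrogen, three ring bonds from the ring atom that bears a fused ring and three from the ring atom that bears a phenyl group; in compound 3 it sits in a five-membered non-aromatic ring with 1 nitrogen, two ring bonds from each of those ring atoms. It is therefore the same kind of change, not the same change.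

Going by the values given here, only one earlier instance exists, on a different core, so the expectation is tentative. In this assay compound 4 is expected to show a 4.4-fold lower number from compound 3 to compound 4 (0.65 log units; beyond the scatter), a step resting on a 6.2-fold lower number from compound 1 to compound 2 (0.79 log units; beyond the scatter). The starting point of that step is the value of compound 3, 8000 nM. Compound 4 is thus estimated at 1800 nM, with a likely range from 600 nM to 5500 nM.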

Compound 4, half-maximal inhibitory concentration: 7300 nM
Compound 4: middle estimate off by 4.1-fold (0.61 log units), on the low side; measured number outside the range, above it.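

On the core of compound 3, pyridin-2-yl in place of 4-nitrophenyl on the amide-type nitrogen gives a 1.1-fold lower number from compound 3 to compound 4 (0.04 log units; within the scatter) in this assay, so no order can be read between these two compounds. Set beside the earlier pair, the same exchange did not carry over from one core to the other: the same change on two cores in this assay, a 6.2-fold lower number (0.79 log units; beyond the scatter) from compound 1 to compound 2 and a 1.1-fold lower number (0.04 log units; within the scatter) from compound 3 to compound 4, 5.7-fold (0.75 log units) apart, beyond the scatter of two such steps This shows that the step seen on the core of compound 1 cannot simply be transferred to the core of compound 3, but with only two pairs it does not show why the cores differ, or which of the two steps a third core would resemble.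

The compounds shown leave open which difference between the cores matters, since the seven-membered ring with 2 nitrogen and the five-membered ring with 1 nitrogen differ both in ring size and in the number of nitrogen atoms. They also leave open how other groups on the amide-type nitrogen, such as a benzyl group or a phenyl ring carrying an amine or a carboxylic acid, would behave on each core, and whether those groups would follow the same exchange on both.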